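Urea pyrazole series: methoxy to hydroxy on compound 2

The source may report more compounds than this note shows. Statements on the series, on what has been measured and on what is new or still open speak of the compounds shown alone.

Among the measured compounds shown here, compound 2 `COc1cc(-c2nn(-c3cccc(NC(=O)Nc4cc(C(F)(F)F)cc(C(F)(F)F)c4)c3)cc2-c2ccncc2)ccc1Cl` holds the lower of the two numbers measured so far: in a functional assay on MDA-MB-231 cells (Homo sapiens) for inhibition, read by sulforhodamine B assay, with a stated time of 48 h (a lower number here means a stronger inhibitor of growth, a higher number a weaker inhibitor of growth), compound 2 gives 664 nM, whereas compound 1 `O=C(Nc1cccc(-n2cc(-c3ccncc3)c(-c3ccc(Cl)c(O)c3)n2)c1)Nc1cccc(C(F)(F)F)c1` gives 3590 nM in this assay, a gap beyond the scatter. Compound 3 `O=C(Nc1cccc(-n2cc(-c3ccncc3)c(-c3ccc(Cl)c(O)c3)n2)c1)Nc1cc(C(F)(F)F)cc(C(F)(F)F)c1` is compound 2 with hydrogen in place of methyl on an oxygen on an aromatic ring. For the measured compounds named here, no measured pair isolates this change, since compound 1 carries the hydroxy together with a different urea aryl group. A loss of potency beyond the scatter is expected, though smaller than the whole gap to compound 1 at 3590 nM. The expected step is a 2.3-fold higher number from compound 2 to compound 3 (0.35 log units; beyond the scatter). Compound 3 is thus estimated at 1500 nM, within 500 nM to 4500 nM.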

Compound 3, concentration for 50% growth inhibition: 739 nM
For compound 3 the middle estimate is 2.0-fold (0.31 log units) above the measured one; measured number inside the range.
By their numbers in this assay, from the lowest: compounds 2 and 3 (each within the scatter of the next); then compound 1.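

In this assay the step of methoxy to hydroxy, a 1.1-fold higher number from compound 2 to compound 3 (0.05 log units; within the scatter), stays within the scatter, so at this oxygen on the aromatic ring the methyl can give way to hydrogen with no readable change. Among the compounds shown here, the first one-place pair on the urea aryl group, trifluoromethyl in place of hydrogen on an aromatic carbon, shows a 4.9-fold lower number from compound 1 to compound 3 (0.69 log units; beyond the scatter), a step beyond the scatter, which places the readable difference at that aromatic carbon rather than at this oxygen. Nothing at hand explains either step. Still open, on these data alone, is whether an amine in place of the hydroxy, or an ethoxy with its longer chain, would stay within the scatter of compound 2 in this assay as well.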